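Swapping the Nitrophenyl Group at a Sensitive Position

The source may report more compounds than this note shows. Statements on the series, on what has been measured and on what is new or still open speak of the compounds shown alone.

compound 1 `NC(=O)Cn1c(=O)n(C2OC(CO)[C@@H](O)[C@H]2O)c2nc(N)nc(O)c21`: 72%
compound 2 `Nc1nc(O)c2c(n1)n(C1OC(CO)[C@@H](O)[C@H]1O)c(=O)n2Cc1ccc([N+](=O)[O-])cc1`: 16%

In a functional assay on the whole organism with Mus musculus as the target (on this read-out higher numbers stand for larger maximal responses and lower numbers for smaller maximal responses), compound 1 gives 72%, while compound 2 gives 16%, the lowest of the two numbers. Compound 3 `Nc1nc(O)c2c(n1)n(C1OC(CO)[C@@H](O)[C@H]1O)c(=O)n2CCN1CCCCC1` differs from compound 2 by (piperidin-1-yl)methyl in place of 4-nitrophenyl on a saturated chain carbon bound to an aromatic nitrogen. Within the data shown here, the only measured step, a number 56 percentage points lower from compound 1 to compound 2 (beyond the scatter), concerns the same place but a different group; it shows that this assay answers strongly to changes there, yet gives no direction for this exchange. A large step of uncertain direction is therefore expected. Compound 3 is expected to give 45%, within 15% to 80%. The estimated step is a number 29 percentage points higher from compound 2 to compound 3 (beyond the scatter).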

Compound 3, largest response reached (reported as maximal response), in percent of the reference or control that the assay uses: 0%
Beside the measured number, compound 3's estimate is 45 percentage points above it; measured number outside the range, below it.
By their numbers in this assay, from the lowest: compound 3; then compound 2; then compound 1.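

On the saturated chain carbon bound to an aromatic nitrogen, (piperidin-1-yl)methyl in place of 4-nitrophenyl gives in this assay a further fall, a number 16 percentage points lower from compound 2 to compound 3 (beyond the scatter), and in place of carbamoyl it gives a number 72 percentage points lower from compound 1 to compound 3 (beyond the scatter) as the largest drop among these compounds. Among the three compounds, the response falls with either the aromatic ring of carbon only or the non-aromatic ring with a hetero atom, and carbamoyl gives the highest number. Nothing measured here accounts for this fall.
As far as these compounds go, whether a primary amine, a carboxylic acid or a longer chain ending in carbamoyl at this place would give a response near that of compound 1 remains open.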